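Diethylamino for Dimethylamino on the Amide Side Chain

The source may hold more compounds than are shown below. What is called first, only, known or untested is meant among the compounds shown, and "the series" means these compounds.

compound 1 `CCn1c(C(=O)NCCCN(C)C)ccc1C(CC)(CC)c1ccc(OCCC(O)(CC)CC)c(C)c1`: 5 nM
compound 2 `CCn1c(C(=O)NCCN(C)C)ccc1C(CC)(CC)c1ccc(OCCC(O)(CC)CC)c(C)c1`: 82 nM

Going by the values given here, in an assay on cells for agonist activity at vitamin D3 receptor (Homo sapiens), with a stated time of 96 h (a lower number here means that less compound is needed, a higher number that more compound is needed for the effect), compound 2 gives 82 nM, the higher of the two numbers measured so far, while compound 1 gives 5 nM. Among the compounds with values here, the only measured step, a 16-fold higher number from compound 1 to compound 2 (1.21 log units; beyond the scatter), concerns the length of the chain and so does not bear on the change to compound 3 `CCN(CC)CCNC(=O)c1ccc(C(CC)(CC)c2ccc(OCCC(O)(CC)CC)c(C)c2)n1CC`, which is diethylamino in place of dimethylamino on a saturated chain carbon, two bonds along the chain from an amide-type nitrogen. Within the data shown here, with no comparable step measured, no step beyond the scatter is expected; compound 3 is expected to show a 1.0-fold lower number from compound 2 to compound 3 (0.01 log units; within the scatter). Compound 3 is therefore estimated at 80 nM, with a range from 25 nM to 250 nM.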

Compound 3, half-maximal effective concentration: 2.3 nM
Beside the measured number, compound 3's estimate is 35-fold (1.54 log units) above it; the whole stated range lies above it.
By their numbers in this assay, from the lowest: compound 3; then compound 1; then compound 2.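

Changing the amine end of the side chain matters as much as changing its length: diethylamino in place of dimethylamino gives a 36-fold lower number from compound 2 to compound 3 (1.55 log units; beyond the scatter). This gain outweighs the cost of the shorter chain, since the step to the diethylamino compound is a 2.2-fold lower number from compound 1 to compound 3 (0.34 log units; beyond the scatter). Nothing shown gives a reason for the size of these steps. From the compounds shown here alone, it remains open whether diethylamino would bring a similar gain on the longer chain of compound 1. Also open, going by these compounds, is how a larger dipropylamino group or a ring amine such as piperidine would compare on the shorter chain.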